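Cytotoxicity notes: chloro to fluoro on the aromatic ring

The source may report more compounds than this note shows. Statements on the series, on what has been measured and on what is new or still open speak of the compounds shown alone.

Compound 1 `CCC1(Cc2ccccc2)OS(=O)(=O)C=C1OCc1ccc(Cl)cc1` is the reference point. In an ADME assay on HEL cells (Homo sapiens) for cytotoxicity, with a stated time of 3 days (on this read-out higher numbers stand for lower toxicity in this test and lower numbers for higher toxicity in this test), compound 1 gives > 200000 nM, which is a limit of the assay rather than a number. Compound 2 `CCC1(Cc2ccccc2)OS(=O)(=O)C=C1OCCCCCCc1ccccc1` differs elsewhere. In this assay compound 2 gives < 200000 nM, likewise a limit. Within the data shown here, no step between the two is measured; the values only show one at each limit (the limit of < 200000 nM in this assay, at which 1 of the 2 values shown sits, (the limit of > 200000 nM in this assay, at which 1 of the 2 values shown sits)). Compound 3 `CCC1(Cc2ccccc2)OS(=O)(=O)C=C1OCc1ccc(F)cc1` is not yet measured and carries fluoro in place of chloro on an aromatic carbon. In this assay the expected step is a step that the limit leaves unreadable from compound 1 to compound 3, none beyond the scatter. Compound 3 is therefore expected near 250000 nM, between 100000 nM and 600000 nM.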

Compound 3, half-maximal cytotoxic concentration: > 50000 nM
Compound 3: no number, only a limit; the forecaster's own chance of this, stated with the estimate: 70%; the middle value is on the limit's open side.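

Among these compounds, compound 1 and compound 3 both stand only as limits in this assay, so no step between them can be read. As far as these compounds go, how far fluoro in place of chloro moves the half-maximal cytotoxic concentration, and in which direction, stays open.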